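Sulfonamide nitrogen: oxazole swapped for pyrimidine

A few compounds are considered here, and "the series" means these few. Any claim that something is new, unique, unknown or untested is made for them only; others in the source may bear on it.

The series shares the core shown for compound 2 `NS(=O)(=O)c1ccc(N/C(S)=N\c2ccnc3cc(C(F)(F)F)ccc23)cc1`, which carries an unsubstituted sulfonamide nitrogen and in a functional assay on HepG2 cells (Homo sapiens) for antiproliferative activity, read by sulforhodamine B assay, with a stated time of 48 h (on this read-out lower numbers stand for stronger inhibition and higher numbers for weaker inhibition), gives 52200 nM. Compound 1 `O=C(Nc1ccccc1)Nc1ccc(S(=O)(=O)Nc2ccnc3cc(C(F)(F)F)ccc23)cc1`, with a urea link instead of the thiourea, is recorded as "not active" (no number reported) in this assay and offers no number. For the measured compounds named here, compound 3 `Cc1cc(NS(=O)(=O)c2ccc(N/C(S)=N\c3ccnc4cc(C(F)(F)F)ccc34)cc2)on1`, bearing 3-methyl-1,2-oxazol-5-yl on the sulfonamide nitrogen, gives 28500 nM in this assay; its value and that of compound 2 lie within the scatter of each other, the only other entry being compound 1 without a number. Going by the values given here, the single step with a value, a 1.8-fold lower number from compound 2 to compound 3 (0.26 log units; within the scatter), shows that adding an aromatic group to that nitrogen left the read-out essentially unchanged.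

Compound 4 `O=S(=O)(Nc1ncccn1)c1ccc(N/C(S)=N\c2ccnc3cc(C(F)(F)F)ccc23)cc1` differs from compound 3 by pyrimidin-2-yl in place of 3-methyl-1,2-oxazol-5-yl on a sulfonamide nitrogen. Among the compounds with values here, the one bearing step, from compound 2 to compound 3, was within the scatter, and the present change keeps the same count of heavy atoms and acceptors at the same place, so no step beyond the scatter is expected in either direction in this assay. Compound 4 is therefore expected at 30000 nM, with a range of 12000 nM to 75000 nM, corresponding to an estimated step of a 1.1-fold higher number from compound 3 to compound 4 (0.02 log units; within the scatter).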

Compound 4, half-maximal inhibitory concentration: 42100 nM
For compound 4 the middle estimate is 1.4-fold (0.15 log units) below the measured one; the measured number falls inside the stated range.
By their numbers in this assay, from the lowest: compounds 3, 4 and 2 (each within the scatter of the next).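

In this assay, for the compounds shown here, the exchange of the five-membered 3-methyl-1,2-oxazol-5-yl for the six-membered pyrimidin-2-yl on the sulfonamide nitrogen stays within the scatter (a 1.5-fold higher number from compound 3 to compound 4 (0.17 log units; within the scatter)), so this position now has a comparison between two aromatic groups, which the earlier compounds did not offer. Set against hydrogen at the same nitrogen, pyrimidin-2-yl also stays within the scatter (a 1.2-fold lower number from compound 2 to compound 4 (0.09 log units; within the scatter)), which makes it the second aromatic group, after 3-methyl-1,2-oxazol-5-yl, that leaves the read-out indistinguishable from the unsubstituted sulfonamide, and so compounds 2, 3 and 4 form one flat set with no order among them. No supporting measurement is available that would account for this flat result.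

From the compounds shown here alone, whether anything other than hydrogen and these two aromatic rings on the sulfonamide nitrogen can move the number beyond the scatter stays open, for instance an amine-bearing chain, a carboxylic acid or a longer alkyl chain. The contribution of the thiourea link also cannot be read, since compound 1 carries no number and differs from the others in more than one place.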